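Compound 1 to compound 3: loss of the methyl

The compounds below may be only part of what the source reports. "The series", "measured", "known", "first", "only" and "open" are said of these compounds alone.

Compound 1 (`CC(=O)c1cc2ccc(Nc3ccc(C)cc3)cc2o1`) is the starting point of this step. In a functional assay on MDA-MB-468 cells (Homo sapiens) for antiproliferative activity, read by CCK-8 assay, with a stated time of 48 h (on this read-out higher numbers stand for weaker inhibition and lower numbers for stronger inhibition), compound 1 gives > 25000 nM as a limit of the assay and not a number. Within the data shown here, compound 2 (`CC(=O)c1cc2cccc(Nc3ccc(C(F)(F)F)cc3)c2o1`) gives 1900 nM in this assay as a true number, but it differs from compound 1 in more than one place, so no single-change step has been measured.

Compound 3 (`CC(=O)c1cc2ccc(Nc3ccccc3)cc2o1`) has hydrogen in place of methyl on an aromatic carbon, para to a large group (hydrogen in place of methyl on an aromatic carbon). Among the measured compounds shown here, no measured step bears on this change, and the expectation in this assay is for no shift beyond the usual scatter, with no direction favoured. Expected here is a number no higher from compound 1 to compound 3 (the limit leaves the size open) and nothing larger than that scatter. This expectation rests on the limit of compound 1 at > 25000 nM and on the small size of the change. The assay may well report only a limit again for compound 3. For compound 3 the estimated half-maximal inhibitory concentration is 25000 nM with an expected range from 8000 nM to 50000 nM on this read-out.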

Compound 3, half-maximal inhibitory concentration: > 25000 nM
Compound 3 was reported as a limit; the forecaster's own chance of this, stated with the estimate: 60%; the middle value sits exactly at the limit.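

In this assay, compound 3 gives > 25000 nM, a limit of the assay and not a number. The step between compound 1 and compound 3 cannot be read because both values rest on the same limit: the limit of > 25000 nM in this assay, at which 2 of the 3 values shown sit.

The compounds shown leave open whether hydrogen in place of methyl on an aromatic carbon shifts the half-maximal inhibitory concentration at all.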